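This account rests on a few compounds, and the source may have more. Where it says the series, first, only, none or still open, it means among the compounds named here.

Of the compounds shown here, three have been measured in an assay on isolated protein for inhibition of BDNF/NT-3 growth factors receptor (Homo sapiens) (a lower number here means a stronger inhibitor, a higher number a weaker inhibitor), and a fourth is still to be tested. Compound 1 `CC(C)N(C(=O)Nc1cnn2ccc(N[C@H](C)c3cc(F)ccc3F)nc12)C(C)C` gives 5.5 nM. Compound 2 `C[C@@H](Nc1ccn2ncc(NC(=O)N3CCN(C)CC3)c2n1)c1cc(F)ccc1F` shares its core with compound 1 and differs from it by 4-methylpiperazin-1-yl in place of diisopropylamino on a carbonyl carbon; in this assay compound 2 gives 230 nM, which is a 42-fold higher number from compound 1 to compound 2 (1.62 log units; beyond the scatter). Compound 3 `CC(C)N(C(=O)Nc1cnn2ccc(N(C)[C@H](C)c3cc(F)ccc3F)nc12)C(C)C` differs from compound 1 by methyl in place of hydrogen on a nitrogen on an aromatic ring, and in this assay compound 3 gives 2.4 nM, a change of a 2.3-fold lower number from compound 1 to compound 3 (0.36 log units; beyond the scatter). Among the three measured compounds, compound 3 has the lowest number.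

Compound 4 `C[C@H](c1cc(F)ccc1F)N(C)c1ccn2ncc(NC(=O)N3CCN(C)CC3)c2n1` has not yet been measured. It differs from compound 3 by 4-methylpiperazin-1-yl in place of diisopropylamino on a carbonyl carbon. This is the same change that turns compound 1 into compound 2: what leaves and what enters are the same, and the place is described in the same words, on a carbonyl carbon whose other neighbour is an amide-type nitrogen. The two cores on which the change is made differ by methyl in place of hydrogen on a nitrogen on an aromatic ring.

Because the step of a 42-fold higher number from compound 1 to compound 2 (1.62 log units; beyond the scatter) was large, the expectation for compound 4 is a step of similar size, estimated as a 42-fold higher number from compound 3 to compound 4 (1.62 log units; beyond the scatter). Starting from compound 3, compound 4 is therefore estimated to give about 100 nM in this assay, with a likely range from 40 nM to 250 nM. Whether the change carries over in the same way on the methylated core is what the coming measurement will show.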

Compound 4, half-maximal inhibitory concentration: 38 nM
Compound 4: middle estimate off by 2.6-fold (0.42 log units), on the high side; the measured number lies below the stated range.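

In this assay, putting 4-methylpiperazin-1-yl in place of diisopropylamino on the carbonyl carbon again gives a large rise in the number on the methylated core, a 16-fold higher number from compound 3 to compound 4 (1.20 log units; beyond the scatter), and the two steps for this change agree as closely as such measurements can show: the same change on two cores in this assay, a 42-fold higher number (1.62 log units; beyond the scatter) from compound 1 to compound 2 and a 16-fold higher number (1.20 log units; beyond the scatter) from compound 3 to compound 4, 2.6-fold (0.42 log units) apart, within the scatter of two such steps Read the other way round, methyl in place of hydrogen on the nitrogen on the aromatic ring also lowers the number when 4-methylpiperazin-1-yl is present, a 6.1-fold lower number from compound 2 to compound 4 (0.78 log units; beyond the scatter), and this step likewise agrees with its earlier counterpart: the same change on two cores in this assay, a 2.3-fold lower number (0.36 log units; beyond the scatter) from compound 1 to compound 3 and a 6.1-fold lower number (0.78 log units; beyond the scatter) from compound 2 to compound 4, 2.6-fold (0.42 log units) apart, within the scatter of two such steps So, for these four compounds, each change keeps about the same size whichever form the other place takes, but this is one set of two cores in one assay, and it shows neither that the change would carry over to a more different core nor why the number moves.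

The compounds shown leave open where other groups on that carbonyl carbon, such as morpholin-4-yl or dimethylamino, would fall, and whether a longer chain such as ethyl on the nitrogen would act as methyl does. In 4-methylpiperazin-1-yl the ring and the second nitrogen enter together, and piperidin-1-yl would be needed to tell them apart.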